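Switching a nitrophenyl ketone for a benzyl ester on a shared core

A few compounds are considered here, and "the series" means these few. Any claim that something is new, unique, unknown or untested is made for them only; others in the source may bear on it.

Measured so far:
- compound 1, `CC1(C)[C@H](C(=O)OC(c2ccccc2)c2ccccc2)N2C(=O)/C(=C/C(=O)c3ccc([N+](=O)[O-])cc3)[C@H]2[S+]1[O-]`: 48200 nM
- compound 2, `CC1(C)S[C@@H]2/C(=C\C(=O)c3ccc([N+](=O)[O-])cc3)C(=O)N2[C@H]1C(=O)OC(c1ccccc1)c1ccccc1`: 50300 nM

Both compounds were tested in a functional assay on A-375 cells (Homo sapiens) for cytotoxicity, read by MTT assay, with a stated time of 48 h; a higher number here means a weaker inhibitor, a lower number a stronger inhibitor. Compound 1 gives 48200 nM, and compound 2 gives 50300 nM. Compound 2 has the higher of the two numbers, but its nearest neighbour, compound 1, sits within the usual scatter of this assay, so the two cannot be told apart; both are weak inhibitors of A-375 cell growth.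

Compound 3, `CC1(C)S[C@@H]2/C(=C\C(=O)OCc3ccccc3)C(=O)N2[C@H]1C(=O)OC(c1ccccc1)c1ccccc1`, is not yet measured. It differs from compound 2 in one place: benzyloxy in place of 4-nitrophenyl on a carbonyl carbon. Put another way, the (4-nitrophenyl)carbonyl group becomes a benzyloxycarbonyl group, so a ketone attached to the double-bonded chain carbon turns into an ester at the same carbon.

Going by the values given here, no step between measured compounds is available to judge this change, so any expectation rests on the two weak values alone. The step from compound 2 to compound 3 in this assay is expected to be small, with no clear direction beyond the scatter: a 1.2-fold higher number from compound 2 to compound 3 (0.08 log units; within the scatter). Compound 3 is therefore estimated at 60000 nM, within a range from 20000 nM to 200000 nM.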

Compound 3, half-maximal inhibitory concentration: 7100 nM
Compound 3: middle estimate off by 8.5-fold (0.93 log units), on the high side; measured number outside the range, below it.
By their numbers in this assay, from the lowest: compound 3; then compounds 1 and 2 (each within the scatter of the next).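

In this assay the change from 4-nitrophenyl to benzyloxy on a carbonyl carbon gives a clear shift (a 7.1-fold lower number from compound 2 to compound 3 (0.85 log units; beyond the scatter)), which lies beyond the scatter and shows that what sits on this carbonyl carbon can alter the cell result. The change is not a simple one, since the ketone becomes an ester at the same carbon while the nitro-bearing ring gives way to a benzyl group, and this single step cannot separate those two differences. Nothing measured here accounts for the lower number, so the step stands as an observation with no established cause.

From the compounds shown here alone, it remains open whether the ester link or the loss of the nitro group matters more, a question that a plain phenyl ketone or a benzyl amide at the same carbonyl carbon could help to settle. Going by these compounds, it is also open whether the aromatic ring is needed at all, which a simple methyl ester would test, and whether a longer chain in place of the benzyl group would move the number further.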